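The compounds below may be only part of what the source reports. "The series", "measured", "known", "first", "only" and "open" are said of these compounds alone.

Compound 1 `Cc1ccc(N2C(=O)COc3ccc(-c4cnc5ccccc5c4)cc32)cc1` gives > 40000 nM
Compound 2 `O=C1COc2ccc(-c3cccc(NS(=O)(=O)c4ccc(F)cc4)c3)cc2N1C1CC1` gives > 40000 nM

In a functional assay on HeLa cells (Homo sapiens) for antiproliferative activity, read by MTT assay, with a stated time of 72 h (a higher number here means a weaker inhibitor, a lower number a stronger inhibitor), compound 1 gives > 40000 nM as a limit of the assay, not as a number. Compound 2 gives > 40000 nM as a limit too. The measured picture is thus the limit of > 40000 nM in this assay, at which 2 of the 2 values shown sit, and compound 1 has no number of its own.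

The next compound is compound 3 `O=C1COc2ccc(-c3cnc4ccccc4c3)cc2N1` and its change from compound 1 is hydrogen in place of 4-methylphenyl on an amide-type nitrogen in a ring in short, hydrogen in place of 4-methylphenyl on an amide-type nitrogen in a ring.

Among the compounds with values here, no measured step exists to size this change. In this assay a modest move toward a stronger inhibitor is expected, though the assay may again report only a limit. The estimated step is an at least 1.3-fold lower number from compound 1 to compound 3 (0.12 log units; that floor lies within the scatter) and it is a rough one. For compound 3 the expected value is 30000 nM with an estimated range from 6000 nM to 40000 nM on this reading.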

Compound 3, half-maximal inhibitory concentration: > 40000 nM
Compound 3 was reported as a limit (the forecaster's own chance of this, stated with the estimate: 60%); middle value at least 1.3-fold (0.12 log units) away from the limit.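

Compound 1 and compound 3 both stand at a limit and not at a number, so no step can be read between them: the limit of > 40000 nM in this assay, at which 3 of the 3 values shown sit.

As far as these compounds go, whether hydrogen in place of 4-methylphenyl on an amide-type nitrogen in a ring changes the activity at all remains open.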